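The source may report more compounds than this note shows. Statements on the series, on what has been measured and on what is new or still open speak of the compounds shown alone.

Of the compounds shown here, two have been measured in an assay on isolated protein for inhibition of serine/threonine-protein kinase TNNI3K (Homo sapiens); a higher number here means a weaker inhibitor, a lower number a stronger inhibitor. Compound 1 `CNc1cc(Oc2ccc(NC(=O)Nc3cccc(C(F)F)c3)cc2)ncn1` gives 100 nM. Compound 2 `O=C(Nc1ccc(Oc2cc(O)ncn2)cc1)Nc1cccc(C(F)(F)F)c1` gives 3200 nM, the higher of the two numbers, and these two structures differ in more than one place. Compound 3 `CN(C)c1cc(Oc2ccc(NC(=O)Nc3cccc(C(F)(F)F)c3)cc2)ncn1` is not yet measured. It differs from compound 2 by one change: dimethylamino in place of hydroxy on an aromatic carbon. Among the compounds with values here, no measured pair shows this change on its own, so the size of the step is uncertain. Compound 3 is expected to give a lower number than compound 2, with an estimated step of a 13-fold lower number from compound 2 to compound 3 (1.11 log units; beyond the scatter) in this assay. The estimate for compound 3 is 250 nM, within 60 nM to 1000 nM.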

Compound 3, half-maximal inhibitory concentration: 2500 nM
Compound 3: the middle estimate sits 10-fold (1.00 log units) below what was measured; the measured number lies above the stated range.
By their numbers in this assay, from the lowest: compound 1; then compounds 3 and 2 (each within the scatter of the next).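

In this assay, the step of a 1.3-fold lower number from compound 2 to compound 3 (0.11 log units; within the scatter) shows that this swap on the pyrimidine carbon barely registers: hydroxy and dimethylamino cannot be told apart here, even though the change adds heavy atoms and removes a hydrogen-bond donor. On this core, then, the two groups give numbers within the scatter of each other. No measurement shown explains why the number stays put.

Still open, going by these compounds, is whether a methoxy group or a morpholine ring on this same aromatic carbon would move the number beyond the scatter. Also open, on these data alone, is how a methylamino group would read with the trifluoromethyl group of compound 3 kept in place.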